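Aminopyrimidine series: hydroxyphenyl to methylphenyl on the anilino nitrogen

A few compounds are considered here, and "the series" means these few. Any claim that something is new, unique, unknown or untested is made for them only; others in the source may bear on it.

Of the compounds shown here, three have been measured in a functional assay on HCT-116 cells (Homo sapiens) for antiproliferative activity, read by MTT assay, with a stated time of 72 h; a higher number here means a weaker inhibitor of growth, a lower number a stronger inhibitor of growth. Compound 1 `c1ccc(Cn2c(Nc3ccccc3)nc3ncccc32)cc1` gives 64700 nM, and compound 2 `c1ccc(Cn2c(Nc3ccccc3)nc3cccnc32)cc1` gives 60200 nM. Compound 3 `Cn1nc(-c2ccnc(Nc3ccc(O)cc3)n2)c2ccccc21`, built on a different core, gives 8430 nM. Compound 3 stands lowest of the three numbers: compound 2 lies closest, with a number beyond the scatter above it, and compound 1 furthest, also beyond the scatter. Compounds 1 and 2 differ from each other by an amount within the scatter, so no order is drawn between them.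

Compound 4 `Cc1cccc(Nc2nccc(-c3nn(C)c4ccccc34)n2)c1` keeps the core of compound 3 and changes only the group on the anilino nitrogen: 3-methylphenyl in place of 4-hydroxyphenyl on a nitrogen on an aromatic ring. Going by the values given here, no measured pair in this set shows that change, so its size cannot be read from a reference step. In the absence of such a step, the change from compound 3 to compound 4 is expected to stay within the scatter, with no clear direction. The expected step, a 1.2-fold lower number from compound 3 to compound 4 (0.08 log units; within the scatter), is accordingly small. In this assay compound 4 is estimated to give 7000 nM, with a range from 2000 nM to 25000 nM.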

Compound 4, concentration for 50% growth inhibition: 9420 nM
The estimate for compound 4 lay 1.3-fold (0.13 log units) below the measured number; the range from low to high includes it.
By their numbers in this assay, from the lowest: compounds 3 and 4 (each within the scatter of the next); then compounds 2 and 1 (each within the scatter of the next).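

In this assay, the first step read at this position, a 1.1-fold higher number from compound 3 to compound 4 (0.05 log units; within the scatter), lies within the scatter, with 3-methylphenyl in place of 4-hydroxyphenyl on a nitrogen on an aromatic ring. In this pair, the loss of the hydrogen-bond donor and hydrogen-bond acceptor counted on 4-hydroxyphenyl leaves no change that can be told from the scatter, so neither is shown to be required for the growth inhibition seen on this core. Nothing measured here bears on why the two groups read alike.

The two group names differ in both the substituent and the number of its ring position, so this single step cannot assign any contribution to either difference, and a small net step could also hide opposing contributions. As far as these compounds go, it also remains open whether a group of another kind on the phenyl ring, such as an amine or a carboxylic acid, would move the number beyond the scatter, or whether this position tolerates such groups as it tolerates the two seen so far.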